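A few compounds are considered here, and "the series" means these few. Any claim that something is new, unique, unknown or untested is made for them only; others in the source may bear on it.

Compound 1 `Cc1ccccc1-c1nc(CN2CCC(C(=O)NCCCN3CC(C)(C)CC(C)(C)C3)CC2)c(C)o1` gives > 1390 10^-6 cm/s in a physicochemical assay for permeability, using PAMPA; a higher number here means that the compound crosses the layer faster, a lower number that the compound crosses the layer more slowly.
Compound 2 `CC[C@@H]1C[C@H](CC)CN(CCCNC(=O)C2CCN(Cc3nc(-c4c(F)cccc4F)oc3C)CC2)C1` gives 130 10^-6 cm/s in this assay.

Compound 1 stands only at a limit of this assay, not at a number: the limit of > 1390 10^-6 cm/s in this assay, at which 1 of the 2 values shown sits. Compound 2 gives a plain number. For the measured compounds named here, compound 3 `Cc1ccccc1-c1nc(CN2CCC(C(=O)NCCN3C[C@H](C)C[C@H](C)C3)CC2)c(C)o1` differs from compound 1 in one place, (a group of 8 heavy atoms (7 carbon, 1 nitrogen; one six-membered non-aromatic ring with 1 hetero atom) in place of a group of 11 heavy atoms (10 carbon, 1 nitrogen; one six-membered non-aromatic ring with 1 hetero atom), on a saturated chain carbon, two bonds along the chain from an amide-type nitrogen), and no step between measured compounds is available for comparison. Because compound 1 sits at the limit of > 1390 10^-6 cm/s in this assay, at which 1 of the 2 values shown sits, the step of an at least 1.3-fold lower number from compound 1 to compound 3 (0.14 log units; that floor lies within the scatter) is expected to be small, within the scatter or slightly downward, with compound 3 likely still near that limit. Compound 3 is expected to give 1000 10^-6 cm/s, in a range from 400 10^-6 cm/s to 1390 10^-6 cm/s.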

Compound 3, apparent permeability: 712 10^-6 cm/s
For compound 3 the middle estimate is 1.4-fold (0.15 log units) above the measured one; the range from low to high includes it.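

Replacing the group of 11 heavy atoms in compound 1 with 3,5-dimethylpiperidin-1-yl, on a saturated chain carbon, two bonds along the chain from an amide-type nitrogen, gives an at least 1.9-fold lower number from compound 1 to compound 3 (0.29 log units; that floor lies within the scatter). Compound 3 thus gives a plain number in this assay, so this position now has a reading that is not a limit. The value of compound 1 is a limit and not a number, so the full size of this step stays unknown: the limit of > 1390 10^-6 cm/s in this assay, at which 1 of the 3 values shown sits.

The compounds shown leave open how a morpholine or a simple dimethylamine at this place would read in this assay. They also leave open whether a longer chain to the ring nitrogen would change the reading.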